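A few compounds are considered here, and "the series" means these few. Any claim that something is new, unique, unknown or untested is made for them only; others in the source may bear on it.

Measured so far:
compound 1, `c1cc(-c2cn[nH]c2)c2c(c1)C(c1ncc[nH]1)CC2`: > 10000 nM
compound 2, `Cc1oncc1-c1cccc2c1CCC2c1ncc[nH]1`: > 10000 nM

In a functional assay on CHO cells for agonist activity at Alpha-1B adrenergic receptor (Homo sapiens), read by FLIPR and calcium flux (a higher number here means that more compound is needed for the effect, a lower number that less compound is needed), compound 1 gives > 10000 nM, which is a limit of the assay and not a number. Compound 2 in this assay gives > 10000 nM, likewise a limit. The step that the two limits leave unreadable from compound 1 to compound 2 is therefore unreadable, as both values sit at the limit of > 10000 nM in this assay, at which 2 of the 2 values shown sit. Compound 2 thus stands at the limit of this assay, with nothing to separate it from compound 1.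

Compound 3 is `Cc1n[nH]cc1-c1cccc2c1CCC2c1ncc[nH]1`. The change from compound 2: 3-methyl-1H-pyrazol-4-yl in place of 5-methyl-1,2-oxazol-4-yl on an aromatic carbon. Within the data shown here, the only measured step that bears on it, a step that the two limits leave unreadable from compound 1 to compound 2, exchanges the same two ring types in the opposite sense and shows no readable size; no measured step shows movement beyond the scatter. Compound 1, which carries the 1H-pyrazol-4-yl, gives > 10000 nM as a limit. For compound 3 the expectation is therefore again a limit, estimated at 20000 nM with a range of 8000 nM to 60000 nM. The expected step from compound 2 is a step that the limit leaves unreadable from compound 2 to compound 3, none beyond the scatter.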

Compound 3, half-maximal effective concentration: 902 nM
Estimate against measurement, compound 3: 22-fold (1.35 log units) above; the whole stated range lies above it.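

At this position on the shared core, the group carried clearly matters: in this assay, 3-methyl-1H-pyrazol-4-yl in place of 5-methyl-1,2-oxazol-4-yl gives an at least 11-fold lower number from compound 2 to compound 3 (1.04 log units; beyond the scatter). The methyl matters as well, with methyl in place of hydrogen on an aromatic carbon giving an at least 11-fold lower number from compound 1 to compound 3 (1.04 log units; beyond the scatter), so among these three compounds a readable value appears only where the methyl and the pyrazole ring occur together. The true size of both steps stays undefined, as each starts from a limit: the limit of > 10000 nM in this assay, at which 2 of the 3 values shown sit.

The compounds shown leave open how much room the methyl site allows, for instance with ethyl, trifluoromethyl or an amine in its place. They also leave open whether the ring hydrogen of the pyrazole is needed, which a methyl on that ring nitrogen would address.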